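A new aryl group on the aromatic nitrogen

This account rests on a few compounds, and the source may have more. Where it says the series, first, only, none or still open, it means among the compounds named here.

Compound 2 `Cc1ccc(-n2nncc2CN2C(=O)C3(C(C#N)=C(N)Oc4c3c3nc5ccccc5nc3c3ccccc43)c3ccccc32)c(C)c1` is one of two close relatives measured so far. In an ADME assay on L02 cells (Homo sapiens) for antiproliferative activity, read by MTT assay, with a stated time of 48 h (on this read-out higher numbers stand for weaker inhibition and lower numbers for stronger inhibition), compound 2 gives > 50000 nM, which is a limit of the assay rather than a measured number. Its partner compound 1 `Cc1ccc(-n2nncc2CN2C(=O)C3(C(C#N)=C(N)Oc4c3c3nc5ccccc5nc3c3ccccc43)c3ccccc32)cc1C` differs only in carrying a 3,4-dimethylphenyl group in place of the 2,4-dimethylphenyl group on the aromatic nitrogen. In this assay compound 1 gives > 50000 nM, again a limit of the assay. The step that the two limits leave unreadable from compound 1 to compound 2 therefore cannot be read, since both values sit at the same limit (the limit of > 50000 nM in this assay, at which 2 of the 2 values shown sit). Compound 3 `N#CC1=C(N)Oc2c(c3nc4ccccc4nc3c3ccccc23)C12C(=O)N(Cc1cnnn1-c1ccc(F)c(Cl)c1)c1ccccc12` is not yet measured. It differs from compound 2 by 3-chloro-4-fluorophenyl in place of 2,4-dimethylphenyl on an aromatic nitrogen. Going by the values given here, the one measured step concerns the same position but has no readable size, so it gives no direction; all that is known is that both measured compounds stand at the limit. Compound 3 is therefore expected to stay there as well, with the step of a number no higher from compound 2 to compound 3 (the limit leaves the size open) expected to be nothing beyond the scatter. The estimate for compound 3 in this assay is 50000 nM, within a range from 20000 nM to 100000 nM, with a limit report the most likely outcome.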

Compound 3, half-maximal inhibitory concentration: > 50000 nM
Compound 3 ended at the assay's limit; the forecaster's own chance of this, stated with the estimate: 80%; the middle value lies on the limit itself.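

In this assay, going by these compounds alone, no step among compound 1, compound 2 and compound 3 can be read, because all three values are limits of the assay rather than numbers: the limit of > 50000 nM in this assay, at which 3 of the 3 values shown sit. The compounds shown leave open whether the aryl group on the aromatic nitrogen changes the activity at all, since none of the three gives a measured number.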